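A Halogenated Phenyl in Place of a Nitrophenyl

The source may report more compounds than this note shows. Statements on the series, on what has been measured and on what is new or still open speak of the compounds shown alone.

Going by the values given here, compound 1 `O=C(/C=C/c1ccc([N+](=O)[O-])cc1)Nc1cc2c(Nc3ccc(F)c(Cl)c3)ncnc2cc1O[C@H]1CCOC1` is the only member of this set with a reported number: in a functional assay on A549 cells (Homo sapiens) for cytotoxicity, read by MTT assay, with a stated time of 72 h (a higher number here means a weaker inhibitor, a lower number a stronger inhibitor), compound 1 gives 12000 nM, a weak result. Compound 2 `COc1cc(/C=C/C(=O)Nc2cc3c(Nc4ccc(F)c(Cl)c4)ncnc3cc2OC)cc(OC)c1` differs from it in more than one place, and in this assay compound 2 is recorded as "not active" (no number reported), with no number attached, so it offers nothing to compare against. Compound 3 `O=C(/C=C/c1ccc(F)cc1Cl)Nc1cc2c(Nc3ccc(F)c(Cl)c3)ncnc2cc1O[C@H]1CCOC1` has not yet been measured. It differs from compound 1 in one place: 2-chloro-4-fluorophenyl in place of 4-nitrophenyl on a double-bonded chain carbon bound to a double-bonded chain carbon. Among the compounds with values here, no pair of measured compounds shows what such a change does in this assay, so there is no step to lean on. Because compound 1 already gives 12000 nM in this assay, a shift beyond the scatter is not expected in either direction. The estimated step is a 1.2-fold lower number from compound 1 to compound 3 (0.08 log units; within the scatter). Compound 3 is therefore expected to give 10000 nM, within a range of 4000 nM to 30000 nM, with a real chance that the assay reports only a limit.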

Compound 3, half-maximal inhibitory concentration: 5190 nM
For compound 3 the middle estimate is 1.9-fold (0.28 log units) above the measured one; the range from low to high includes it.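

In this assay, going by these compounds alone, the change gives a 2.3-fold lower number from compound 1 to compound 3 (0.36 log units; beyond the scatter), the first readable step at this position, where the earlier compounds offered no measured pair. It shows that, in this assay, the number at this position responds to the aryl group on the double-bonded chain carbon, and that 4-nitrophenyl is not needed for a measurable result, since 2-chloro-4-fluorophenyl, counted with no hydrogen-bond acceptors, also gives one. Nothing measured here explains why the number falls.

This single step replaces the whole aryl group at once, so the compounds shown leave open how much of the shift belongs to the chlorine, the fluorine or the loss of the nitro group. They also leave open how this position would respond to an amine, a carboxylic acid or a pyridine ring in place of the phenyl.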